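A Bromophenylsulfonyl Swap on the Amine Nitrogen

A few compounds are considered here, and "the series" means these few. Any claim that something is new, unique, unknown or untested is made for them only; others in the source may bear on it.

Compound 1 `CCCCNC(=S)NC1=C(C#N)C(c2ccc(Cl)cc2Cl)C2=C(CCCC2=O)N1c1ccc(S(N)(=O)=O)cc1` gives 30% in a functional assay on Ehrlich cells (Mus musculus) for cytotoxicity, read by trypan blue exclusion, with a stated time of 2 h, tested at 10 ug/mL (a higher number here means a stronger effect of the compound at the concentration tested, a lower number a weaker effect), the highest of the three numbers shown, although the scatter does not separate it from the others. Compound 2 `N#CC1=C(NC(N)=O)N(c2ccc(S(N)(=O)=O)cc2)C2=C(C(=O)CCC2)C1c1ccc(Cl)cc1Cl` gives 20% and compound 3 `N#CC1=C(N2C(=O)CCC2=O)N(c2ccc(S(N)(=O)=O)cc2)C2=C(C(=O)CCC2)C1c1ccc(Cl)cc1Cl` gives 20% in this assay; the steps of a number 10 percentage points lower from compound 1 to compound 2 (within the scatter) and a number 10 percentage points lower from compound 1 to compound 3 (within the scatter) are both within the scatter, as is no change at the digits printed from compound 2 to compound 3 (within the scatter). Compound 4 `N#CC1=C(NS(=O)(=O)c2ccc(Br)cc2)N(c2ccc(S(N)(=O)=O)cc2)C2=C(C(=O)CCC2)C1c1ccc(Cl)cc1Cl` is the new member.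

a group of 10 heavy atoms (6 carbon, 2 oxygen, 1 sulfur, 1 bromine; one six-membered aromatic ring of carbon only) in place of a group of 7 heavy atoms (5 carbon, 1 nitrogen, 1 sulfur; no ring), on an amine nitrogen

Going by the values given here, the only measured step on the same amine nitrogen is the one from compound 1 to compound 2, and it stayed flat; no measured compound carries a (4-bromophenyl)sulfonyl group. Because a number 10 percentage points lower from compound 1 to compound 2 (within the scatter) stayed within the scatter, compound 4 is expected to show no change at the digits printed from compound 1 to compound 4 (within the scatter). The estimate for compound 4 is 30%, between 15% and 45%.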

Compound 4, a percentage reported as activity, at one concentration (the size of the read-out at that concentration, not a potency): 90%
Estimate against measurement, compound 4: 60 percentage points below; measured number above the stated range.
By their numbers in this assay, from the lowest: compounds 2, 3 and 1 (each within the scatter of the next); then compound 4.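

On the amine nitrogen, the earlier exchanges in this assay stayed within the scatter, whereas (4-bromophenyl)sulfonyl gives a number 60 percentage points higher from compound 1 to compound 4 (beyond the scatter) and also a number 70 percentage points higher from compound 2 to compound 4 (beyond the scatter) in the same place. Set against 2,5-dioxopyrrolidin-1-yl on the double-bonded ring carbon, ((4-bromophenyl)sulfonyl)amino gives a number 70 percentage points higher from compound 3 to compound 4 (beyond the scatter) on the shared core, so this position can carry a large difference after all. No evidence bears on the cause of this rise.

Going by these compounds, it remains open whether the rise belongs to the sulfonyl link, the phenyl ring or the bromine. A methylsulfonyl or an unsubstituted phenylsulfonyl group on this amine nitrogen would separate these parts.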